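This account rests on a few compounds, and the source may have more. Where it says the series, first, only, none or still open, it means among the compounds named here.

Compound 2, `CC(C)[C@H](NC(=O)c1ccc(Cl)cc1O)C(=O)Nc1ccc(Cl)c(Cl)c1`, was tested in a functional assay on MCF7 cells (Homo sapiens) for cytotoxicity, with a stated time of 72 h; a higher number here means a weaker inhibitor, a lower number a stronger inhibitor. In this assay compound 2 gives only a limit of > 10000 nM, not a number. Its one measured relative, compound 1, `CC(C)[C@H](NC(=O)c1ccc(Cl)cc1O)C(=O)Nc1ccc(Br)cc1`, carries a 4-bromophenyl where compound 2 carries a 3,4-dichlorophenyl on an amide-type nitrogen. In this assay compound 1 likewise gives only a limit, > 10000 nM. The step that the two limits leave unreadable from compound 1 to compound 2 therefore cannot be sized, and the limit of > 10000 nM in this assay, at which 2 of the 2 values shown sit, is all the two measurements show. Compound 3, `C[C@H](NC(=O)c1ccc(Cl)cc1O)C(=O)Nc1ccc(Cl)c(Cl)c1`, is compound 2 with methyl in place of isopropyl on a saturated chain carbon bound to an amide-type nitrogen and a carbonyl carbon. Going by the values given here, no measured step touches this position, so there is no ground to expect a change beyond the scatter in this assay. The step is expected to be a step that the limit leaves unreadable from compound 2 to compound 3. Compound 3 is expected to give 15000 nM, within 4000 nM to 60000 nM, most probably again reported only as a limit.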

Compound 3, half-maximal inhibitory concentration: > 12500 nM
Compound 3: no number, only a limit; the forecaster's own chance of this, stated with the estimate: 80%; the middle value lies beyond the limit too.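

Compound 2 and compound 3 each give only a limit, not a number, so the effect of methyl in place of isopropyl cannot be sized. The compounds shown leave open how strongly any of them inhibits, and whether either change among them shifts that strength at all.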